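The source may hold more compounds than are shown below. What is called first, only, known or untested is meant among the compounds shown, and "the series" means these compounds.

Compound 1 `O=Cc1cccc(OCc2cn(Cc3ccccc3)nn2)c1` is the smallest member of this set, an aldehyde carrying the benzyl-substituted triazole ether. In a functional assay on PC-3 cells (Homo sapiens) for inhibition, read by MTT assay, with a stated time of 48 h (a higher number here means a weaker inhibitor, a lower number a stronger inhibitor), compound 1 gives > 50000 nM, which is a limit of the assay rather than a number. Compound 2 `O=C1Nc2ccc(Br)cc2/C1=C/c1cccc(OCc2cn(Cc3ccccc3)nn2)c1` joins that fragment to a fused core bearing a bromo group. In this assay compound 2 gives > 50000 nM, again only a limit. Compound 3 `O=C1Nc2ccc(F)cc2/C1=C\c1cccc(OCc2cn(Cc3ccccc3)nn2)c1` carries a fluoro group instead of bromo. In this assay compound 3 gives > 50000 nM, once more a limit. Going by the values given here, compound 3 therefore stands where every value so far stands, at the limit of > 50000 nM in this assay, at which 3 of the 3 values shown sit, and no ordering among the three can be read from such values. Compound 4 `O=C1Nc2ccc(C(=O)c3ccccc3)cc2/C1=C\c1cccc(OCc2cn(Cc3ccccc3)nn2)c1` is the next member. It differs from compound 3 by benzoyl in place of fluoro on an aromatic carbon. Among the compounds with values here, no step between measured compounds exists to guide the size of this change. The expected step is an at least 1.2-fold lower number from compound 3 to compound 4 (0.09 log units; that floor lies within the scatter), toward stronger inhibition but without confidence that it clears the scatter. Compound 4 is thus expected to give 40000 nM in this assay, within 8000 nM to 100000 nM.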

Compound 4, half-maximal inhibitory concentration: > 50000 nM
Compound 4 ended at the assay's limit; the forecaster's own chance of this, stated with the estimate: 60%; at least 1.2-fold (0.09 log units) between middle value and limit.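

Compound 3 and compound 4 both end at a limit of the assay rather than at a number, so no step can be read between them: the limit of > 50000 nM in this assay, at which 4 of the 4 values shown sit.

How strongly any of these compounds inhibits in this assay, and whether benzoyl or fluoro makes any difference there, stays open.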